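Swapping the aryl group on the ring nitrogen

The compounds below may be only part of what the source reports. "The series", "measured", "known", "first", "only" and "open" are said of these compounds alone.

Measured so far, all in a functional assay on MGC-803 cells (Homo sapiens) for antiproliferative activity, read by CCK-8 assay, with a stated time of 72 h, tested at 8 uM; on this read-out lower numbers stand for a weaker effect and higher numbers for a stronger effect at the one concentration tested:
compound 1 `Nc1ccccc1NC(=O)c1ccc(CSC(=S)N2CCN(Cc3ccncc3)CC2)cc1` gives 79.3%
compound 2 `Nc1ccccc1NC(=O)c1ccc(CSC(=S)N2CCN(c3ccccc3F)CC2)cc1` gives 86.4%
compound 3 `CN(C(=S)SCc1ccc(C(=O)Nc2ccccc2N)cc1)c1cccnc1` gives 82.5%

Compound 2 holds the highest of the three numbers, yet compound 3 and compound 1 both sit within the scatter of it, so no order among them can be read. Compound 4 `N#Cc1ccc(N2CCN(C(=S)SCc3ccc(C(=O)Nc4ccccc4N)cc3)CC2)cc1` differs from compound 2 by 4-cyanophenyl in place of 2-fluorophenyl on an amine nitrogen in a ring. Among the measured compounds shown here, the one measured step at the same ring nitrogen, a number 7.1 percentage points higher from compound 1 to compound 2 (within the scatter), stayed within the scatter, and the value of compound 3, which also carries a different group there, lies close to compound 2. A change at this position is therefore expected to move the number little, with the step of a number 2.4 percentage points lower from compound 2 to compound 4 (within the scatter) estimated as none beyond the scatter. Compound 4 is expected to give about 84%, within 72% to 93%.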

Compound 4, a percentage reported as inhibition, at one concentration (the size of the read-out at that concentration, not a potency): 37.6%
Compound 4: middle estimate off by 46.4 percentage points, on the high side; measured number outside the range, below it.
By their numbers in this assay, from the lowest: compound 4; then compounds 1, 3 and 2 (each within the scatter of the next).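

The group on this ring nitrogen can matter a great deal in this assay: 4-cyanophenyl brings a number 48.8 percentage points lower from compound 2 to compound 4 (beyond the scatter) and a number 41.7 percentage points lower from compound 1 to compound 4 (beyond the scatter), both large and beyond the scatter. The earlier compounds shown here gave no sign of a change this large at this position. Nothing measured here explains the drop.

Still open, as far as these compounds go, is whether the loss follows the nitrile itself or its place on the phenyl ring. A 4-fluorophenyl or a 2-cyanophenyl group on the same nitrogen would separate these two readings.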